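The source may hold more compounds than are shown below. What is called first, only, known or untested is meant among the compounds shown, and "the series" means these compounds.

In an ADME assay for permeability, using PAMPA (a lower number here means that the compound crosses the layer more slowly, a higher number that the compound crosses the layer faster), three compounds have been measured so far:
compound 1 `O=C(Nc1ccc(Cl)cc1)c1cc([N+](=O)[O-])ccc1Cl` gives 536 10^-6 cm/s;
compound 2 `C=C(C)C(=O)Nc1cccc(-c2nc3ccccc3s2)c1` gives 987 10^-6 cm/s;
compound 3 `O=C(CCl)Nc1cccc(-c2nc3ccccc3s2)c1` gives 660 10^-6 cm/s.

Among these numbers, compound 3 lies within the usual scatter of both compound 1 and compound 2, so the three cannot be told apart with confidence. Compound 4 `O=C(Nc1cccc(-c2nc3ccccc3s2)c1)c1ccc(Cl)nc1Cl` has not yet been measured; it differs from compound 3 by 2,6-dichloropyridin-3-yl in place of chloromethyl on a carbonyl carbon. Among the compounds with values here, only one measured step alters the same place: a 1.5-fold lower number from compound 2 to compound 3 (0.17 log units; within the scatter), which left the number unchanged within the scatter. Within the data shown here, the change to compound 4 brings in a ring group that no measured pair covers, so nothing here points to a shift in this assay in either direction. Compound 4 is therefore expected at 600 10^-6 cm/s, with a range from 300 10^-6 cm/s to 1000 10^-6 cm/s. This amounts to an expected step of a 1.1-fold lower number from compound 3 to compound 4 (0.04 log units; within the scatter).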

Compound 4, apparent permeability: 104 10^-6 cm/s
For compound 4 the middle estimate is 5.8-fold (0.76 log units) above the measured one, outside the stated range (below it).
By their numbers in this assay, from the lowest: compound 4; then compounds 1, 3 and 2 (each within the scatter of the next).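

In this assay the group on this carbonyl carbon can matter after all. Putting 2,6-dichloropyridin-3-yl there gives a 6.3-fold lower number from compound 3 to compound 4 (0.80 log units; beyond the scatter) and a 9.5-fold lower number from compound 2 to compound 4 (0.98 log units; beyond the scatter) and both steps lie beyond the scatter, whereas the swap between two small groups, a 1.5-fold lower number from compound 2 to compound 3 (0.17 log units; within the scatter) stayed within it. Nothing measured here explains the drop. As far as these compounds go, it remains open whether the ring itself or its two chlorine atoms go with the lower number: an unsubstituted phenyl or pyridin-3-yl ring at this place would separate the two.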